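A Carbamoyl Becomes a Carboxy at the Assay Limit

The source may hold more compounds than are shown below. What is called first, only, known or untested is meant among the compounds shown, and "the series" means these compounds.

Of the compounds shown here, two sharing an unsaturated acid chain have been tested so far. In a functional assay on A549 cells (Homo sapiens) for antiproliferative activity (on this read-out higher numbers stand for weaker inhibition and lower numbers for stronger inhibition), compound 1 `C/C(=C\Cc1cccc(C(N)=O)n1)CCC(=O)O` gives > 100000 nM, which is a limit of the assay and not a number. In this assay, compound 2 `C/C(=C\Cn1cnc(C(N)=O)n1)CCC(=O)O` gives > 100000 nM, again a limit. Compound 2 therefore stands at the limit of > 100000 nM in this assay, at which 2 of the 2 values shown sit, and no measured number places it more exactly.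

The next compound is compound 3 `C/C(=C\Cn1cnc(C(=O)O)n1)CCC(=O)O`, which differs from compound 2 in one place: hydroxy in place of amino on a carbonyl carbon. In words, this puts hydroxy in place of amino on a carbonyl carbon, turning carbamoyl to carboxy.

Within the data shown here, no measured step between the tested compounds shows what size of change to look for in this assay. The expectation therefore rests on compound 2 alone, and it is for no step beyond the usual scatter, with compound 3 most likely reported as a limit again. The expected change is a number no higher from compound 2 to compound 3 (the limit leaves the size open). Compound 3 is estimated at 100000 nM, with an expected range from 50000 nM to 200000 nM.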

Compound 3, half-maximal inhibitory concentration: > 100000 nM
Compound 3: only a limit was reported; the forecaster's own chance of this, stated with the estimate: 90%; the middle value sits exactly at the limit.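

In this assay compound 3 gives > 100000 nM, which is a limit of the assay and not a number. Compound 2 also stands at a limit, so no step can be read between compound 2 and compound 3. The compounds shown leave open what carboxy in place of carbamoyl does to a measurable potency, with every value at one ceiling: the limit of > 100000 nM in this assay, at which 3 of the 3 values shown sit.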